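The source may hold more compounds than are shown below. What is called first, only, known or untested is meant among the compounds shown, and "the series" means these compounds.

Measured so far:
compound 1 `CCCCOC(=O)CNC(=O)[C@H](CSc1ccc([N+](=O)[O-])cc1[N+](=O)[O-])NC(=O)CC[C@H](N)C(=O)OCCCC`: 107 uM
compound 2 `CCCCCCCCCCCCCC(=O)N[C@@H](CCC(=O)N[C@@H](CSc1ccc([N+](=O)[O-])cc1[N+](=O)[O-])C(=O)NCC(=O)OCCCC)C(=O)OCCCC`: > 300 uM

The read-out is a toxicity assay on KB cells (Homo sapiens) for cytotoxicity, read by fluorescence, with a stated time of 3 days; on this read-out lower numbers stand for an effect already at smaller amounts and higher numbers for an effect only at larger amounts of compound. Compound 1 gives 107 uM in this assay, the only plain number shown. For compound 2 this assay reports only a limit, > 300 uM (the limit of > 300 uM in this assay, at which 1 of the 2 values shown sits). Compound 3 `CCCCOC(=O)CNC(=O)[C@H](CSc1ccc([N+](=O)[O-])cc1[N+](=O)[O-])NC(=O)CC[C@H](NC(=O)C(C)(C)C)C(=O)OCCCC` is not yet measured and differs from compound 1 by (tert-butyl)carbonyl in place of hydrogen on an amine nitrogen. Compound 2 also carries a carbonyl group on that nitrogen. Within the data shown here, no measured step of this kind exists, so for compound 3 the step of a 1.7-fold higher number from compound 1 to compound 3 (0.23 log units; within the scatter) is expected to be modest, toward effect only at larger amounts. Compound 3 is expected at 180 uM, between 80 uM and 400 uM.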

Compound 3, concentration for half-maximal effect: 83.4 uM
Beside the measured number, compound 3's estimate is 2.2-fold (0.33 log units) above it; low and high end bracket the measured number.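

In this assay, placing (tert-butyl)carbonyl on the amine nitrogen gives a 1.3-fold lower number from compound 1 to compound 3 (0.11 log units; within the scatter). Among these compounds, this is the first readable step at this position, and it shows that a hydrogen can give way to a group of 6 heavy atoms with no change beyond the usual scatter. Compound 2 has only a limit, so no step to it can be read: the limit of > 300 uM in this assay, at which 1 of the 3 values shown sits.

Still open, from the compounds shown here alone, is how an acetyl or a benzoyl group on this amine nitrogen would read in this assay.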